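Substituent changes on the aromatic nitrogen of the shared core

The compounds below may be only part of what the source reports. "The series", "measured", "known", "first", "only" and "open" are said of these compounds alone.

Measured so far in an assay on HEK293 cells for inhibition of Leucine-rich repeat serine/threonine-protein kinase 2 variant G2019S (Homo sapiens), with a stated time of 48 h; on this read-out lower numbers stand for stronger inhibition and higher numbers for weaker inhibition:
- compound 1 `Cc1c(Nc2nc(N)c3c(C#N)c(N4CCC[C@H]4C)n(C)c3n2)cnn1C`: 260 nM
- compound 2 `Cc1nn(C2COC2)cc1Nc1nc(N)c2c(C#N)c(N3CCC[C@H]3C)n(C)c2n1`: 140 nM
- compound 3 `Cc1nn(C2CCOC2)cc1Nc1nc(N)c2c(C#N)c(N3CCC[C@H]3C)n(C)c2n1`: 65 nM; 180 nM (2 entries)

Compound 2 gives the lowest of the two single numbers in this assay; the nearest is compound 1, and the step of a 1.9-fold lower number from compound 1 to compound 2 (0.27 log units; within the scatter) lies within the scatter. Compound 3 carries two entries rather than one number, (the several entries of compound 3 in this assay, 65 nM; 180 nM (2 entries)), which shows how far repeats of a single compound in this assay can sit apart.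

Compound 4 `Cc1nn(CC(C)(C)O)cc1Nc1nc(N)c2c(C#N)c(N3CCC[C@H]3C)n(C)c2n1` is not yet measured. It differs from compound 2 by 2-hydroxy-2-methylpropyl in place of oxetan-3-yl on an aromatic nitrogen. Among the measured compounds shown here, the only measured step at this position, a 1.9-fold lower number from compound 1 to compound 2 (0.27 log units; within the scatter), stays within the scatter, and the spread of the repeats of compound 3, (the several entries of compound 3 in this assay, 65 nM; 180 nM (2 entries)), is of the same order. Changes on this nitrogen have so far moved the number no further than the scatter allows, so no step beyond the scatter is expected here either. Compound 4 is therefore estimated at 150 nM in this assay, with a range of 60 nM to 400 nM. This corresponds to an expected step of a 1.1-fold higher number from compound 2 to compound 4 (0.03 log units; within the scatter).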

Compound 4, half-maximal inhibitory concentration: 180 nM
The estimate for compound 4 lay 1.2-fold (0.08 log units) below the measured number; the range from low to high includes it.
By their numbers in this assay, from the lowest: compounds 2, 4 and 1 (each within the scatter of the next).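

Among the compounds shown here, the step of a 1.3-fold higher number from compound 2 to compound 4 (0.11 log units; within the scatter) is the first at this position that replaces a ring with an open chain: the four-membered ring of oxetan-3-yl gives way to 2-hydroxy-2-methylpropyl, which also brings a hydrogen-bond donor that oxetan-3-yl lacks. In this assay, neither difference separates compound 4 from compound 2, so the ring is not required for a number in this range. Repeats of a single compound sit at least as far apart as this step, so no ranking of these substituents can be drawn: the several entries of compound 3 in this assay, 65 nM; 180 nM (2 entries).

Still open, going by these compounds, is whether an amine or a carboxylic acid on this nitrogen, or a longer chain carrying either group, would move the number beyond the scatter. So far, no substituent on this nitrogen stands apart from the others.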